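Replacing the aryl amide of compound 3 with a piperazinyl acetyl group

A few compounds are considered here, and "the series" means these few. Any claim that something is new, unique, unknown or untested is made for them only; others in the source may bear on it.

Measured compounds:
compound 1 `CC1=NN(S(=O)(=O)c2ccc([N+](=O)[O-])cc2)C(c2cc(Br)cc(Br)c2O)C1` — "not active" (no number reported)
compound 2 `CC(=O)Oc1ccccc1C1CC(C)=NN1C(=O)CN(C(C)C)C(C)C` — 34100 nM
compound 3 `O=C(c1ccccc1Cl)N1N=C(c2cc3ccccc3oc2=O)CC1c1ccccc1` — 5440 nM

In a functional assay on HepG2 cells (Homo sapiens) for cytotoxicity, read by MTT assay, with a stated time of 48 h (on this read-out lower numbers stand for stronger inhibition and higher numbers for weaker inhibition), compound 3 gives 5440 nM, the lowest of the two numbers reported. Compound 2 gives 34100 nM in this assay, a number beyond the scatter above that of compound 3, and compound 1 is reported in this assay as "not active" (no number reported) without a number. For the measured compounds named here, no pair of measured compounds differs in a single place, so no measured step guides the change at hand.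

Compound 4 `CN1CCN(CC(=O)N2N=C(c3cc4ccccc4oc3=O)CC2c2ccccc2)CC1` keeps the core of compound 3 and differs from it in one place: (4-methylpiperazin-1-yl)methyl in place of 2-chlorophenyl on a carbonyl carbon. Going by the values given here, since compound 3 is the only measured compound with this core, the direction of the step cannot be read from a neighbour. On the numbers shown, with compound 2 at 34100 nM as the only other entry, a moderate rise in the number, toward weaker inhibition, is expected for compound 4, about a 2.2-fold higher number from compound 3 to compound 4 (0.34 log units; beyond the scatter). Compound 4 is therefore estimated at 12000 nM, within a range of 4000 nM to 40000 nM.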

Compound 4, half-maximal inhibitory concentration: 33100 nM
The estimate for compound 4 lay 2.8-fold (0.44 log units) below the measured number, within the range that was stated.
By their numbers in this assay, from the lowest: compound 3; then compounds 4 and 2 (each within the scatter of the next).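

In this assay the change on the carbonyl carbon gives a 6.1-fold higher number from compound 3 to compound 4 (0.78 log units; beyond the scatter) and so provides the first single-place comparison among these compounds, showing that this position responds to the group it carries. On the core of compound 3, (4-methylpiperazin-1-yl)methyl does not keep the lower number seen with 2-chlorophenyl. The step exchanges a six-membered aromatic ring of carbon only for a six-membered non-aromatic ring with 2 hetero atoms, and nothing shown here explains the rise.

On these data alone, it remains open whether phenyl without the chlorine, or another aromatic ring such as pyridine, would stay closer to compound 3. Also open, as far as these compounds go, is where morpholin-4-ylmethyl or dimethylaminomethyl on the same carbonyl carbon would fall relative to compound 3 and compound 4.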